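A Piperidine Swap Near the Assay's Limit

The source may report more compounds than this note shows. Statements on the series, on what has been measured and on what is new or still open speak of the compounds shown alone.

Within the data shown here, in a functional assay on MCF7 cells (Homo sapiens) for inhibition, read by MTT assay, with a stated time of 72 h (on this read-out higher numbers stand for weaker inhibition and lower numbers for stronger inhibition), compound 1 `CC(C)COC(=O)NCCOc1ccc(Cl)cc1C(=O)N[C@H](C(=O)Nc1ccc([N+](=O)[O-])cc1Cl)C(C)C` gives 10100 nM, the only true number in this small set. Compound 2 `CC(C)[C@H](NC(=O)c1cc(Cl)ccc1OCCCCN)C(=O)Nc1ccc([N+](=O)[O-])cc1Cl` reads > 10000 nM, which is a limit of the assay and not a number. Compound 3 `CC(C)[C@H](NC(=O)c1cc(Cl)ccc1OC1CCN(C(=O)OC(C)(C)C)CC1)C(=O)Nc1ccc([N+](=O)[O-])cc1Cl` reads > 10000 nM, which is also a limit. Together these results define the picture so far: the limit of > 10000 nM in this assay, at which 2 of the 3 values shown sit.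

Compound 4 `CC(C)[C@H](NC(=O)c1cc(Cl)ccc1OC1CCNCC1)C(=O)Nc1ccc([N+](=O)[O-])cc1Cl` carries piperidin-4-yl in place of 2-((isobutoxycarbonyl)amino)ethyl on an oxygen on an aromatic ring. Among the measured compounds shown here, the one measured step that alters this same side chain is a step that the limit leaves unreadable from compound 1 to compound 2. It offers no size to carry over, but compound 2 still gives no readable inhibition at > 10000 nM, so nothing points to a clear gain. No change beyond the usual scatter is therefore expected in this assay. The expected step is a 1.0-fold lower number from compound 1 to compound 4 (0.00 log units; within the scatter). For compound 4, the estimated value is 10000 nM, with an expected range of 4000 nM to 25000 nM.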

Compound 4, half-maximal inhibitory concentration: > 10000 nM
Compound 4 gave a limit, no number (the forecaster's own chance of this, stated with the estimate: 60%); the middle value sits exactly at the limit.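

In this assay compound 4 reads > 10000 nM and this is a limit of the assay, not a number. Its steps from compound 1, compound 2 and compound 3 therefore cannot be read. The compounds shown leave open how far any of these side chains changes inhibition, since only one true number stands against the limit: the limit of > 10000 nM in this assay, at which 3 of the 4 values shown sit.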